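Methylating the Phenol Hydroxy in Two Related Series

A few compounds are considered here, and "the series" means these few. Any claim that something is new, unique, unknown or untested is made for them only; others in the source may bear on it.

Measured compounds:
compound 1 `COc1cc2c(cc1O)C(=O)/C(=C/c1cc(OC)c(OC)c(OC)c1)C2`: > 10000 nM
compound 2 `COc1cc2c(cc1O)C(=O)/C(=C/c1ccc(OC)c(OC)c1OC)C2`: 3140 nM
compound 3 `COc1cc2c(cc1OC)C(=O)/C(=C/c1cc(OC)c(OC)c(OC)c1)C2`: > 10000 nM

Of the compounds shown here, three have been tested in a functional assay on PC-3 cells (Homo sapiens) for antiproliferative activity, read by MTT assay, with a stated time of 48 h; a higher number here means a weaker inhibitor of growth, a lower number a stronger inhibitor of growth. Compound 1 `COc1cc2c(cc1O)C(=O)/C(=C/c1cc(OC)c(OC)c(OC)c1)C2` gives > 10000 nM in this assay, which is a limit and not a number. Compound 3 `COc1cc2c(cc1OC)C(=O)/C(=C/c1cc(OC)c(OC)c(OC)c1)C2` likewise gives > 10000 nM in this assay, again a limit. Among the measured compounds shown here, compound 2 `COc1cc2c(cc1O)C(=O)/C(=C/c1ccc(OC)c(OC)c1OC)C2` is the only compound with a measured number: in this assay compound 2 gives 3140 nM. The difference between the core of compound 1 and the core of compound 2 is not broken down here.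

Compound 1 and compound 3 differ by one change, (methyl in place of hydrogen on an oxygen on an aromatic ring), and the step that the two limits leave unreadable from compound 1 to compound 3 cannot be read because the limit of > 10000 nM in this assay, at which 2 of the 3 values shown sit, sets both values at the same limit.

Compound 4 `COc1cc2c(cc1OC)C(=O)/C(=C/c1ccc(OC)c(OC)c1OC)C2` has not yet been measured. It relates to compound 2 by the same change, (methyl in place of hydrogen on an oxygen on an aromatic ring), and the two places are the same word for word. Since the earlier step is not readable, it gives no size to carry over; the expectation for compound 4 therefore rests on compound 2 at 3140 nM alone, and a step of about a 1.4-fold higher number from compound 2 to compound 4 (0.16 log units; within the scatter) is estimated, neither clearly stronger nor clearly weaker. Compound 4 is expected to give about 4500 nM in this assay, within 1500 nM to 10000 nM.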

Compound 4, concentration for 50% growth inhibition: > 10000 nM
Compound 4: a limit, no number; the forecaster's own chance of this, stated with the estimate: 30%; at least 2.2-fold (0.34 log units) between middle value and limit.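

In this assay, the change from hydroxy to methoxy on the core of compound 2 gives an at least 3.1-fold higher number from compound 2 to compound 4 (0.50 log units; beyond the scatter), so on this core the free hydroxy goes with the stronger inhibition of growth, and the step lies beyond the scatter. Compound 4 sits at a limit rather than a number, so this step gives only the smallest size the change can have on this core, not its true size. The same change on the core of compound 1 cannot be read, so the series shows the change on one core only and cannot say whether its size carries from one core to the other, because both ends of that other step sit at one limit: the limit of > 10000 nM in this assay, at which 3 of the 4 values shown sit.

What the compounds shown leave open is how the hydroxy on the core of compound 2 would compare with groups other than methoxy, such as an ethoxy or longer alkoxy chain, an amine or a carboxylic acid. They also leave open how far compound 4 lies past its limit, and whether any replacement for the hydroxy on this core would keep the growth inhibition of compound 2.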